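Shortening the Amide Side Chain to a Primary Amine

The source may hold more compounds than are shown below. What is called first, only, known or untested is meant among the compounds shown, and "the series" means these compounds.

Compound 3 `CCn1c(C(=O)NCCCN(C)C)ccc1C(CC)(CC)c1ccc(OCC(O)C(C)(C)C)c(C)c1` gives 37 nM in an assay on HL-60 cells for agonist activity at vitamin D3 receptor (Homo sapiens), read by microscopy, with a stated time of 96 h (on this read-out higher numbers stand for an effect only at larger amounts of compound and lower numbers for an effect already at smaller amounts), the second highest of three numbers: close to compound 2 `CCN(CC)CCCNC(=O)c1ccc(C(CC)(CC)c2ccc(OCC(=O)C(C)(C)C)c(C)c2)n1CC`, which gives 22 nM, and separated from compound 1 `CCn1c(C(=O)NCCCN(C)C)ccc1C(CC)(CC)c1ccc(OCC(=O)C(C)(C)C)c(C)c1`, which gives 96 nM. Compound 4 `CCn1c(C(=O)NCCN)ccc1C(CC)(CC)c1ccc(OCC(O)C(C)(C)C)c(C)c1` differs from compound 3 by amino in place of (dimethylamino)methyl on a saturated chain carbon, two bonds along the chain from an amide-type nitrogen. Among the compounds with values here, only the step of a 4.4-fold lower number from compound 1 to compound 2 (0.64 log units; beyond the scatter) touches this end of the molecule; there a larger amine went with a lower number, so taking away the whole dimethylamino arm is expected to push the number up by a modest step. The step of a 2.6-fold lower number from compound 1 to compound 3 (0.41 log units; beyond the scatter) concerns the other end and adds nothing here. Compound 4 is therefore expected to give 90 nM, within 30 nM to 300 nM, a step of a 2.4-fold higher number from compound 3 to compound 4 (0.39 log units; beyond the scatter).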

Compound 4, half-maximal effective concentration: 10 nM
Compound 4: the middle estimate sits 9.0-fold (0.95 log units) above what was measured; the measured number lies below the stated range.
By their numbers in this assay, from the lowest: compound 4; then compounds 2 and 3 (each within the scatter of the next); then compound 1.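

The step of a 3.7-fold lower number from compound 3 to compound 4 (0.57 log units; beyond the scatter) shows that this end of the molecule does not need the dimethylamino arm: the shorter chain ending in a plain amino group goes with a lower number. The larger amine in a 4.4-fold lower number from compound 1 to compound 2 (0.64 log units; beyond the scatter) also lowered the number, though with the ketone rather than the alcohol at the other end, so amine size alone does not order these compounds. Nothing measured here explains this result. Still open, as far as these compounds go, is whether the chain length or the amine type matters: a 3-aminopropyl or a 2-(dimethylamino)ethyl group on the amide nitrogen would separate them.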